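From 3,4-dimethylphenyl to 2,4-dimethylphenyl at the assay limit

The source may hold more compounds than are shown below. What is called first, only, known or untested is meant among the compounds shown, and "the series" means these compounds.

Measured in an ADME assay on K562 cells (Homo sapiens) for cytotoxicity, read by MTT assay, with a stated time of 48 h (a higher number here means a weaker inhibitor, a lower number a stronger inhibitor), all as limits:
- Compound 1 `COc1cc2c(cc1OC)CN(CCn1cc(COc3ccc([N+](=O)[O-])cc3)nn1)CC2`: > 100000 nM
- Compound 2 `COc1cc2c(cc1OC)CN(CCn1cc(COc3ccc(C)cc3)nn1)CC2`: > 100000 nM
- Compound 3 `COc1cc2c(cc1OC)CN(CCn1cc(COc3ccc(C)c(C)c3)nn1)CC2`: > 100000 nM

Compound 3 gives > 100000 nM, which is a limit and not a number. It shares that position with the other two compounds, as the limit of > 100000 nM in this assay, at which 3 of the 3 values shown sit, shows.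

The next compound, compound 4 `COc1cc2c(cc1OC)CN(CCn1cc(COc3ccc(C)cc3C)nn1)CC2`, has the same atoms as compound 3, joined differently: 2,4-dimethylphenyl in place of 3,4-dimethylphenyl on an oxygen on a saturated carbon. In words, 2,4-dimethylphenyl stands in place of 3,4-dimethylphenyl on an oxygen on a saturated carbon.

Among the compounds with values here, three measured steps bear on this change: a step that the two limits leave unreadable from compound 1 to compound 2, a step that the two limits leave unreadable from compound 2 to compound 3 and a step that the two limits leave unreadable from compound 1 to compound 3. None of them gives a size that can be carried over, so the expectation rests only on (the limit of > 100000 nM in this assay, at which 3 of the 3 values shown sit).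

The expected step is a number no higher from compound 3 to compound 4 (the limit leaves the size open), which means no expected change in either direction beyond the usual scatter. For compound 4 the estimated value is 100000 nM, with an expected range from 50000 nM to 200000 nM.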

Compound 4, half-maximal inhibitory concentration: > 100000 nM
Compound 4 was reported as a limit; the forecaster's own chance of this, stated with the estimate: 85%; the middle value lies on the limit itself.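

Compound 4 gives a limit and not a number, so its steps from compound 1, compound 2 and compound 3 cannot be read: the limit of > 100000 nM in this assay, at which 4 of the 4 values shown sit.

The compounds shown leave open whether 2,4-dimethylphenyl and 3,4-dimethylphenyl differ at all in this assay, and how strongly any of these compounds acts there.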